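The source may hold more compounds than are shown below. What is called first, only, known or untested is meant among the compounds shown, and "the series" means these compounds.

Compound 1 `O=C1NC(=O)/C(=C\c2ccc(OCC(=O)N3N=C(c4ccc(F)cc4)CC3c3ccccc3)cc2)S1`: > 50000 nM in an assay on cells for inhibition of histone deacetylase 8 (Homo sapiens), read by fluorescence, with a stated time of 30 min; on this read-out higher numbers stand for weaker inhibition and lower numbers for stronger inhibition.
Compound 2 `O=C1NC(=O)/C(=C\c2ccc(OCC(=O)N3N=C(c4ccc(F)cc4)CC3c3ccco3)cc2)S1`: > 50000 nM in this assay.
Compound 3 `O=C1NC(=O)/C(=C\c2ccc(OCC(=O)N3N=C(c4ccc(F)cc4)CC3c3ccc(F)cc3F)cc2)S1`: > 50000 nM in this assay.

Each of these three values is a limit of this assay rather than a measured number, so compound 2 stands at the limit with no number of its own, just as the other two do: the limit of > 50000 nM in this assay, at which 3 of the 3 values shown sit. Compound 4 `O=C1NC(=O)/C(=C\c2ccc(OCC(=O)N3N=C(c4ccc(F)cc4F)CC3c3ccco3)cc2)S1` differs from compound 2 by fluoro in place of hydrogen on an aromatic carbon. The measured steps that touch this small series are a step that the two limits leave unreadable from compound 1 to compound 2, a step that the two limits leave unreadable from compound 1 to compound 3 and a step that the two limits leave unreadable from compound 2 to compound 3; none of them can be read in size, so they offer no direction for the change to compound 4. Given (the limit of > 50000 nM in this assay, at which 3 of the 3 values shown sit), the step to compound 4 is expected to be a number no higher from compound 2 to compound 4 (the limit leaves the size open). Compound 4 is therefore estimated at 50000 nM, with a range from 15000 nM to 200000 nM.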

Compound 4, half-maximal inhibitory concentration: > 50000 nM
Compound 4: a limit, no number (the forecaster's own chance of this, stated with the estimate: 85%); the middle value lies on the limit itself.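

Compound 4 also sits at a limit, so no step can be read in size between compound 2 and compound 4, or among compounds 1 to 3. The compounds shown leave open what change to the shared core would bring a measurable number: the limit of > 50000 nM in this assay, at which 4 of the 4 values shown sit.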